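Removing the hydroxy from compound 1: an expected limit

A few compounds are considered here, and "the series" means these few. Any claim that something is new, unique, unknown or untested is made for them only; others in the source may bear on it.

Compounds measured in an assay on isolated protein for inhibition of thiosulfate sulfurtransferase (Homo sapiens), with a stated time of 60 min, in the absence of a further agent; on this read-out higher numbers stand for weaker inhibition and lower numbers for stronger inhibition:
compound 1 `O=C(Nc1ccc(Sc2nc3ccccc3s2)c(Cl)c1)c1ccccc1O` gives > 100000 nM, a limit of the assay.
compound 2 `O=C(Nc1ccc(Sc2nc3ccccc3s2)cc1)c1ccccc1O` gives > 100000 nM, likewise a limit.
compound 3 `O=C(Nc1ccc(Sc2nc3ccccc3s2)cc1)c1cc(Br)cc(Br)c1` gives > 100000 nM, again a limit.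

Compound 1 thus stands at the limit of > 100000 nM in this assay, at which 3 of the 3 values shown sit, with no number of its own. The step to compound 4 `O=C(Nc1ccc(Sc2nc3ccccc3s2)c(Cl)c1)c1ccccc1` is hydrogen in place of hydroxy on an aromatic carbon. Among the compounds with values here, two measured steps bear on this series, a step that the two limits leave unreadable from compound 1 to compound 2 and a step that the two limits leave unreadable from compound 2 to compound 3, and neither can be read in size. Nothing here points to a change in this assay, so no step beyond the scatter is expected. Compound 4 is therefore expected to remain at the limit, near 100000 nM, with a range from 30000 nM to 300000 nM. The expected step is a number no higher from compound 1 to compound 4 (the limit leaves the size open).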

Compound 4, half-maximal inhibitory concentration: > 100000 nM
Compound 4 was reported as a limit (the forecaster's own chance of this, stated with the estimate: 85%); the middle value lies on the limit itself.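

Within the data shown here, compound 1 and compound 4 both stand at a limit of the assay, so no step between them can be read in size: the limit of > 100000 nM in this assay, at which 4 of the 4 values shown sit. The compounds shown leave open whether the hydroxy matters at all in this assay, and how strongly any of them inhibits.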